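A few compounds are considered here, and "the series" means these few. Any claim that something is new, unique, unknown or untested is made for them only; others in the source may bear on it.

The compounds share one core, with an aromatic group hanging off each side on a double-bonded chain carbon. Compound 1 is `C=CCn1c(=O)/c(=C\c2cc(F)ccc2C)[nH]c(=O)/c1=C\c1ccccc1OC`. In a functional assay on NCI-H1975 cells (Homo sapiens) for cytotoxicity, read by CCK-8 assay, with a stated time of 72 h (on this read-out higher numbers stand for weaker inhibition and lower numbers for stronger inhibition), compound 1 gives 7300 nM, the highest of the two numbers reported. Compound 2, `COc1ccccc1/C=c1\c(=O)[nH]/c(=C/c2ccccc2Cl)c(=O)n1C`, gives 200 nM in this assay, and the gap between these two lies well beyond the usual scatter. Compound 3, `C=CCn1c(=O)/c(=C\c2cccc(Br)c2)[nH]c(=O)/c1=C\c1cccc(Br)c1`, gives "not active" (no number reported) in this assay, with no number attached.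

Compound 4 is `C=CCn1c(=O)/c(=C\c2cccc(Cl)c2)[nH]c(=O)/c1=C\c1ccccc1OC`. It differs from compound 1 in one place: 3-chlorophenyl in place of 5-fluoro-2-methylphenyl on a double-bonded chain carbon bound to an aromatic carbon. Among the measured compounds shown here, no measured pair in this set differs by just this change, so the step has to be judged from the whole picture. Compound 2, the only potent entry, carries a chlorine on one of its aromatic groups, but it also differs from compound 1 elsewhere, and compound 3, whose two aromatic groups each carry a halogen, was not active at all. I expect the step from compound 1 to compound 4 to be a 1.5-fold lower number from compound 1 to compound 4 (0.16 log units; within the scatter), modest and uncertain in direction. Compound 4 is therefore estimated at 5000 nM, within a range from 1000 nM to 30000 nM.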

Compound 4, half-maximal inhibitory concentration: 5100 nM
For compound 4 the middle estimate is 1.0-fold (0.01 log units) below the measured one; low and high end bracket the measured number.
By their numbers in this assay, from the lowest: compound 2; then compounds 4 and 1 (each within the scatter of the next).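

In this assay, putting 3-chlorophenyl in place of 5-fluoro-2-methylphenyl on a double-bonded chain carbon bound to an aromatic carbon gives a 1.4-fold lower number from compound 1 to compound 4 (0.16 log units; within the scatter), so the two compounds cannot be told apart. Among the compounds shown here, this is the first direct look at this position, since no earlier pair differed in one place only, and it shows that this exchange of one substituted phenyl for another, which removes the fluorine and the methyl and brings in a chlorine, leaves the read-out unchanged within the scatter. Nothing measured here bears on why the exchange makes so little difference.

On these data alone, both groups in this step are six-membered aromatic rings of carbon that carry only a halogen or a methyl, so it remains open whether a ring bearing an amine or a carboxylic acid, or a longer chain in place of the ring, would move the number. Also open, as far as these compounds go, is whether the same exchange would read the same way with a different group on the other side of the shared core.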